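The source may report more compounds than this note shows. Statements on the series, on what has been measured and on what is new or still open speak of the compounds shown alone.

Measured compounds:
compound 1, `Fc1cccc(-c2nc(Nc3ccccc3)c3cc(F)ccc3n2)c1`: 48300 nM
compound 2, `COc1ccc(Nc2nc(-c3cccc(F)c3)nc3ccc(F)cc23)cc1`: 42300 nM
compound 3, `Fc1cccc(-c2nc(Nc3ccc(Cl)cc3)c3cc(F)ccc3n2)c1`: 40300 nM

These three share one core and differ only in the group on the amino nitrogen. In a functional assay on HT29-AK cells (Homo sapiens) for cytotoxicity, read by MTT assay, with a stated time of 48 h (on this read-out lower numbers stand for stronger inhibition and higher numbers for weaker inhibition), compound 1 gives 48300 nM, compound 2 gives 42300 nM and compound 3 gives 40300 nM. Compound 3 sits at the low end of the three numbers, yet the steps leading there, a 1.2-fold lower number from compound 1 to compound 3 (0.08 log units; within the scatter) and a 1.0-fold lower number from compound 2 to compound 3 (0.02 log units; within the scatter), are both within the scatter, as is a 1.1-fold lower number from compound 1 to compound 2 (0.06 log units; within the scatter). Compound 4, `Fc1cccc(-c2nc(Nc3cccc(Cl)c3)c3cc(F)ccc3n2)c1`, keeps the same atoms and changes only their arrangement: 3-chlorophenyl in place of 4-chlorophenyl on a nitrogen on an aromatic ring. For the measured compounds named here, no measured pair moves the chlorine around this ring, but every change made so far on this ring has left the number essentially where it was. Compound 4 is therefore expected to show a 1.0-fold higher number from compound 3 to compound 4 (0.02 log units; within the scatter), and its estimated value is 42000 nM, within a range of 20000 nM to 85000 nM.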

Compound 4, half-maximal inhibitory concentration: > 50000 nM
Compound 4: a limit, no number; the forecaster's own chance of this, stated with the estimate: 10%; at least 1.1-fold (0.07 log units) between middle value and limit.
By their numbers in this assay, from the lowest: compounds 3, 2 and 1 (each within the scatter of the next). At a limit, above all of these: compound 4.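

In this assay compound 4, with its 3-chlorophenyl group, gives a limit and not a number: > 50000 nM. The steps to it are therefore floors only: an at least 1.2-fold higher number from compound 3 to compound 4 (0.09 log units; that floor lies within the scatter), an at least 1.1-fold higher number from compound 2 to compound 4 (0.07 log units; that floor lies within the scatter) and an at least 1.0-fold higher number from compound 1 to compound 4 (0.01 log units; that floor lies within the scatter); all three floors lie within the scatter, so this change cannot yet be told apart from the earlier ones on this ring. What is new is that this ring change gives the first result without a number: the limit of > 50000 nM in this assay, at which 1 of the 4 values shown sits.

As far as these compounds go, how far compound 4 truly lies from the other three stays open. So does the effect of an amine or a carboxylic acid in place of the chlorine.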